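Acyclic uracil series: tolerance in HepG2 cells

A few compounds are considered here, and "the series" means these few. Any claim that something is new, unique, unknown or untested is made for them only; others in the source may bear on it.

Measured so far:
compound 1 `CCc1cn(COC(CO)CO)c(=O)[nH]c1=O` — > 410000 nM (a limit)
compound 2 `O=c1[nH]c(=O)n(COC(CO)CO)cc1CO` — > 406000 nM (a limit)

In a functional assay on HepG2 cells (Homo sapiens) for cytotoxicity (a higher number here means that more compound is tolerated, a lower number that less compound is tolerated), compound 2 gives > 406000 nM, which is a limit of the assay and not a number. Compound 1 gives > 410000 nM in this assay, likewise a limit. The step that the two limits leave unreadable from compound 1 to compound 2 is therefore not readable; the limit of > 406000 nM in this assay, at which 1 of the 2 values shown sits, and the limit of > 410000 nM in this assay, at which 1 of the 2 values shown sits, mark where the two values sit, and nothing in the pair shows a difference beyond the scatter.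

Compound 3 `O=c1[nH]c(=O)n(COC(CO)CO)cc1/C=C/Br` differs from compound 2 by 2-bromoethenyl in place of hydroxymethyl on an aromatic carbon. Among the measured compounds shown here, no measured step touches this change; the only step is the unreadable one from compound 1 to compound 2. With both measured compounds sitting at the top of the assay, compound 3 is expected to stay near that limit, so the step of an at least 1.3-fold lower number from compound 2 to compound 3 (0.13 log units; that floor lies within the scatter) is expected to be small or unreadable. Compound 3 is therefore estimated at 300000 nM, within 60000 nM to 500000 nM, with a fair chance that only a limit is reported.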

Compound 3, half-maximal cytotoxic concentration: > 311000 nM
Compound 3: a limit, no number; the forecaster's own chance of this, stated with the estimate: 55%; middle value at least 1.0-fold (0.01 log units) away from the limit.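

In this assay compound 3 gives > 311000 nM, a limit and not a number. Among the compounds shown here, no step among compound 1, compound 2 and compound 3 can be read. The compounds shown leave open what concentration would be half-maximally cytotoxic for any of them, and whether these substituent changes alter it.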